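Heptyl to 4-bromophenyl on a Chalcone-Triazole Series

The compounds below may be only part of what the source reports. "The series", "measured", "known", "first", "only" and "open" are said of these compounds alone.

Three compounds were tested in a functional assay on SK-N-SH cells (Homo sapiens) for inhibition, read by MTT assay; a higher number here means a weaker inhibitor, a lower number a stronger inhibitor. Compound 1 `CCCCCCCCn1cc(/C=C/C(=O)c2ccc(N)cc2)nn1` gives 28800 nM. Compound 2 `CCCCCCCCn1cc(/C=C/C(=O)c2ccc(NC(=O)CN3CCN(c4ccc([N+](=O)[O-])cc4)CC3)cc2)nn1` gives 51400 nM, and compound 3 `O=C(CN1CCN(c2ccc([N+](=O)[O-])cc2)CC1)Nc1ccc(C(=O)/C=C/c2cn(Cc3ccc(Br)cc3)nn2)cc1` gives 26500 nM. The difference between the cores of compound 1 and compound 2 is not broken down here. From compound 2 to compound 3 the change is 4-bromophenyl in place of heptyl on a saturated chain carbon bound to an aromatic nitrogen, and it made a 1.9-fold lower number from compound 2 to compound 3 (0.29 log units; within the scatter). Compound 4 `Nc1ccc(C(=O)/C=C/c2cn(Cc3ccc(Br)cc3)nn2)cc1` carries the same change against compound 1: 4-bromophenyl in place of heptyl on a saturated chain carbon bound to an aromatic nitrogen. Because the measured step of a 1.9-fold lower number from compound 2 to compound 3 (0.29 log units; within the scatter) lies within the scatter, compound 4 is expected to differ little from compound 1, and the estimate is a 1.6-fold lower number from compound 1 to compound 4 (0.20 log units; within the scatter). Compound 4 is therefore estimated at 18000 nM in this assay, with a likely range from 7000 nM to 45000 nM.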

Compound 4, half-maximal inhibitory concentration: 25200 nM
Compound 4: middle estimate off by 1.4-fold (0.15 log units), on the low side; the range from low to high includes it.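

In this assay the change from heptyl to 4-bromophenyl gave a 1.1-fold lower number from compound 1 to compound 4 (0.06 log units; within the scatter). Set beside the earlier step, the change reads alike on the two cores: the same change on two cores in this assay, a 1.9-fold lower number (0.29 log units; within the scatter) from compound 2 to compound 3 and a 1.1-fold lower number (0.06 log units; within the scatter) from compound 1 to compound 4, 1.7-fold (0.23 log units) apart, within the scatter of two such steps. This shows no detectable difference in how the change behaves on the core of compound 1 and the core of compound 2, but each step lies within the scatter, so it does not show that the change moves the number on either core, and two cores cannot establish a rule for the series.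

The compounds shown leave open whether a larger step would appear with an amine or a carboxylic acid in place of the 4-bromophenyl, or with a longer chain in place of heptyl. They also leave open how the change reads on any other core.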